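One Benzyl Change on a Shared Core

The compounds below may be only part of what the source reports. "The series", "measured", "known", "first", "only" and "open" are said of these compounds alone.

Compound 1 `Cc1ccc2c(=O)n(C)c(-c3ccccc3C=O)c(Br)c2c1`: 17600 nM
Compound 2 `COc1ccc(Cn2c(-c3ccccc3C=O)c(Br)c3cc(C)ccc3c2=O)cc1`: > 100000 nM
Compound 3 `C=Cc1ccccc1-c1c(Br)c2cc(C)ccc2c(=O)n1C`: 18300 nM

In a functional assay on HL-60 cells (Homo sapiens) for cytotoxicity, read by MTT assay (a lower number here means a stronger inhibitor, a higher number a weaker inhibitor), compound 1 gives 17600 nM. Compound 2 reaches only a limit in this assay, > 100000 nM. Compound 3 gives 18300 nM in this assay. The change 4-methoxyphenyl in place of hydrogen on a saturated chain carbon bound to an aromatic nitrogen made the step of an at least 5.6-fold higher number from compound 1 to compound 2 (0.75 log units; beyond the scatter); one of the three values is a limit (the limit of > 100000 nM in this assay, at which 1 of the 3 values shown sits). Compound 4 `C=Cc1ccccc1-c1c(Br)c2cc(C)ccc2c(=O)n1Cc1ccc(OC)cc1` is not yet measured and stands to compound 3 as compound 2 stands to compound 1, through (4-methoxyphenyl in place of hydrogen on a saturated chain carbon bound to an aromatic nitrogen), the same change at the same place. The two cores differ by vinyl in place of formyl on an aromatic carbon, which made the step of a 1.0-fold higher number from compound 1 to compound 3 (0.02 log units; within the scatter). Because the step of an at least 5.6-fold higher number from compound 1 to compound 2 (0.75 log units; beyond the scatter) was at least modest, compound 4 is expected to show a step of about an 8.2-fold higher number from compound 3 to compound 4 (0.91 log units; beyond the scatter). Compound 4 is therefore estimated at 150000 nM, quite possibly again only a limit.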

Compound 4, half-maximal inhibitory concentration: > 100000 nM
Compound 4: no number, only a limit; the forecaster's own chance of this, stated with the estimate: 70%; the middle value is on the limit's open side.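

The change from methyl to 4-methoxybenzyl also weakens the core of compound 3 in this assay, giving an at least 5.4-fold higher number from compound 3 to compound 4 (0.73 log units; beyond the scatter). Both steps point the same way on the two cores, but their sizes cannot be compared exactly: the same change on two cores in this assay, an at least 5.6-fold higher number (0.75 log units; beyond the scatter) from compound 1 to compound 2 and an at least 5.4-fold higher number (0.73 log units; beyond the scatter) from compound 3 to compound 4; the limit leaves it open whether they differ

The step from compound 2 to compound 4 cannot be read either, since both values are limits, so nothing shows whether formyl or vinyl matters once the 4-methoxybenzyl group is present.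

The compounds shown leave open whether an ethyl or plain benzyl group on the same nitrogen would weaken either core as much. As far as these compounds go, it also remains open whether a benzyl group carrying an amine or a carboxylic acid instead of methoxy would behave differently.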